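This account rests on a few compounds, and the source may have more. Where it says the series, first, only, none or still open, it means among the compounds named here.

Compound 1, `Cc1[nH]c2ccccc2c(=O)c1Cc1ccccc1`, gives 102 10^-6 cm/s in an ADME assay for permeability, using PAMPA, at pH 7.4; a lower number here means that the compound crosses the layer more slowly, a higher number that the compound crosses the layer faster.
Compound 2, `Cc1[nH]c2ccccc2c(=O)c1Br`, gives 13.6 10^-6 cm/s in this assay.
Compound 3, `CCCCCCCc1c(C)[nH]c2cc(OC)c(Cl)cc2c1=O`, gives < 0.01 10^-6 cm/s in this assay; this is a limit of the assay, not a number.

Within the data shown here, of the three measured compounds, compound 3 is the one whose result is only a limit: it sits at the limit of < 0.01 10^-6 cm/s in this assay, at which 1 of the 3 values shown sits, so its true value is known only to lie at that boundary or beyond it, and no step between it and either of the other two compounds can be sized. Compounds 1 and 2 both return numbers, the value of compound 1 standing above that of compound 2.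

Compound 4, `COc1cc2[nH]c(C)c(C)c(=O)c2cc1Cl`, has not yet been measured in this assay. It differs from compound 3 in one place: hydrogen in place of hexyl on a saturated chain carbon bound to an aromatic carbon.

Since compound 3 itself has only a limit, the step to compound 4 cannot be anchored to a measured number. The writer nonetheless expects the change from compound 3 to compound 4 to move the value upward, and by more than the usual scatter, the expected step being an at least 800-fold higher number from compound 3 to compound 4 (2.90 log units; beyond the scatter). For compound 4 the estimate in this assay is 8 10^-6 cm/s, with a range from 0.8 10^-6 cm/s to 50 10^-6 cm/s.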

Compound 4, apparent permeability: 59.2 10^-6 cm/s
Compound 4: the middle estimate sits 7.4-fold (0.87 log units) below what was measured; the whole stated range lies below it.
By their numbers in this assay, from the lowest: compound 2; then compounds 4 and 1 (each within the scatter of the next). At a limit, below all of these: compound 3.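

Among these compounds, for the first time, a single change can be followed in this assay: hydrogen in place of hexyl on a saturated chain carbon bound to an aromatic carbon gives an at least 5900-fold higher number from compound 3 to compound 4 (3.77 log units; beyond the scatter). Read one bond further out as heptyl to methyl, this change shows that, with the rest of the structure held constant, the chain at this position alone separates a result at the limit from a measured number, a contrast that the earlier compounds could not isolate. Compound 3 has only a limit of the assay, so the step gives a floor and its true size remains unknown: the limit of < 0.01 10^-6 cm/s in this assay, at which 1 of the 4 values shown sits.

The compounds shown cover only the two ends of this change, so they leave open whether the value falls gradually as the chain grows or drops sharply at some length, a question that an ethyl or butyl chain, or a short chain ending in an amine or a carboxylic acid, could help to settle. Going by these compounds, whether a heptyl chain would have a similar effect on the core of compound 1 also remains open.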